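The compounds below may be only part of what the source reports. "The series", "measured", "known", "first", "only" and "open" are said of these compounds alone.

Measured so far:
compound 1, `Cc1nc2c3ccccc3ccc2c2nc3c(ccc4ccccc43)c(-c3nccnc3N)c12`: 2260 nM
compound 2, `Cc1nc2c3ccccc3ccc2c2nc3c(ccc4ccccc43)c(-c3ccccc3N)c12`: 12100 nM

Both values come from a functional assay on AGS cells (Homo sapiens) for cytotoxicity, read by MTT assay, with a stated time of 48 h; a lower number here means a stronger inhibitor, a higher number a weaker inhibitor. For the measured compounds named here, compound 2 gives the highest number of the two measured in this assay; its nearest neighbour is compound 1, separated by the one recorded step, a 5.4-fold higher number from compound 1 to compound 2 (0.73 log units; beyond the scatter), which exchanges 3-aminopyrazin-2-yl for 2-aminophenyl on an aromatic carbon.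

Compound 3, `Cc1nc2c3ccccc3ccc2c2nc3c(ccc4ccccc43)c(-c3ccccc3Cl)c12`, is not yet measured. It differs from compound 2 in a single place: chloro in place of amino on an aromatic carbon. The place is an aromatic carbon of a six-membered aromatic ring of carbon only, ortho to a large group; read one bond further out, 2-aminophenyl becomes 2-chlorophenyl.

Going by the values given here, no measured step swaps amino for chloro. Among the compounds with values here, the only step on record, a 5.4-fold higher number from compound 1 to compound 2 (0.73 log units; beyond the scatter), alters the aromatic ring that carries the amino group rather than the amino group itself, so it offers no direct guide to the present change. Without a precedent, no step beyond the scatter is assumed in either direction. The expected step, a 1.2-fold higher number from compound 2 to compound 3 (0.09 log units; within the scatter), is estimated to fall within the scatter. In this assay compound 3 is therefore expected near 15000 nM, with a range of 5000 nM to 45000 nM.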

Compound 3, half-maximal inhibitory concentration: 52500 nM
The estimate for compound 3 lay 3.5-fold (0.54 log units) below the measured number; measured number outside the range, above it.
By their numbers in this assay, from the lowest: compound 1; then compound 2; then compound 3.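

In this assay, chloro is not an equivalent replacement for amino on this aromatic carbon, ortho to a large group: there is a 4.3-fold higher number from compound 2 to compound 3 (0.64 log units; beyond the scatter), so changing the substituent itself moves the number beyond the scatter, which the earlier step, confined to the ring carrying the amino group, could not show. Read against the pyrazine-bearing compound, the same position gives a 23-fold higher number from compound 1 to compound 3 (1.37 log units; beyond the scatter), and among the three compounds the one without an amino group gives the highest number. No measurement available here bears on the reason for this shift.

The three compounds do not separate the loss of amino from the entry of chloro, so the reading of this carbon would change with a hydrogen, a hydroxyl, a methyl or a fluoro group in the same place. Also open, going by these compounds, is whether the amino-to-chloro step carries over to the other ring, as a 3-chloropyrazin-2-yl group would show, and whether a methylamino or dimethylamino group keeps the number of the parent amine.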